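A few compounds are considered here, and "the series" means these few. Any claim that something is new, unique, unknown or untested is made for them only; others in the source may bear on it.

Measured compounds:
compound 1, `CCCOc1ccccc1C1CC(=O)c2ccccc2O1`: 44600 nM
compound 2, `CCOc1ccccc1C1CC(=O)c2ccccc2O1`: 38800 nM

Both numbers come from a functional assay on J774.A1 cells (Mus musculus) for inhibition, read by Griess assay, with stated times of 1 h and 24 h; a lower number here means a stronger inhibitor, a higher number a weaker inhibitor. For the measured compounds named here, compound 2 and compound 1 sit within the scatter of each other, so neither can be set apart; the only measured step, a 1.1-fold lower number from compound 1 to compound 2 (0.06 log units; within the scatter), has no direction that can be relied on. The next compound is compound 3, `CCCCCOc1ccccc1C1CC(=O)c2ccccc2O1`. Against compound 2 it shows (propyl in place of hydrogen on a saturated chain carbon, two bonds along the chain from an oxygen on an aromatic ring). Going by the values given here, the one step that bears on it is a 1.1-fold lower number from compound 1 to compound 2 (0.06 log units; within the scatter), which altered the same chain at the same place and stayed within the scatter. The new change extends that chain further than anything measured here, so no step beyond the scatter is predicted in this assay, though the wider range leaves room for a somewhat weaker inhibitor. Compound 3 is therefore expected near 50000 nM (range 20000 nM to 125000 nM), an expected step of a 1.3-fold higher number from compound 2 to compound 3 (0.11 log units; within the scatter).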

Compound 3, half-maximal inhibitory concentration: 39300 nM
Beside the measured number, compound 3's estimate is 1.3-fold (0.10 log units) above it; the measured number falls inside the stated range.
By their numbers in this assay, from the lowest: compounds 2, 3 and 1 (each within the scatter of the next).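

In this assay, the step from ethoxy to pentyloxy gives a 1.0-fold higher number from compound 2 to compound 3 (0.01 log units; within the scatter), and ethyl in place of hydrogen, three bonds along the chain from the oxygen on the aromatic ring, gives a 1.1-fold lower number from compound 1 to compound 3 (0.05 log units; within the scatter). The insensitivity to chain length seen with the first small change therefore now holds out to pentyloxy: compounds 1, 2 and 3 cannot be set apart, and no trend with chain length appears among them. Nothing available explains this flat result.

Still open, as far as these compounds go, is whether any group at this position can move the number beyond the scatter, such as a longer chain than pentyloxy or a chain ending in an amine or a carboxylic acid. From the compounds shown here alone, the effect of changes elsewhere on the shared core also remains open.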